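This account rests on a few compounds, and the source may have more. Where it says the series, first, only, none or still open, it means among the compounds named here.

Compound 1 `CC(C)(C)CNC(=O)C[C@H](NC(=O)CCc1ccccc1)C(=O)N[C@@H](CCc1ccccc1)C(=O)NCc1ccccc1` gives 12 nM in an assay on HEK293 cells for inhibition of nuclear factor NF-kappa-B complex (Homo sapiens), read by a luciferase reporter, with stated times of 1 h and 3 h; a higher number here means a weaker inhibitor, a lower number a stronger inhibitor; compound 2 `CC(C)(C)CNC(=O)C[C@H](NC(=O)c1ccc(C(C)(C)C)cc1)C(=O)N[C@@H](CCc1ccccc1)C(=O)NCc1ccccc1` gives 32 nM; compound 3 `CC(C)(C)CNC(=O)C[C@H](NC(=O)C(=O)c1c[nH]c2ccccc12)C(=O)N[C@@H](CCc1ccccc1)C(=O)NCc1ccccc1` gives 25 nM.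

Compound 3 sits near compound 2, within the scatter of it, while its gap to compound 1 is beyond the scatter. Compound 4 `Cc1cc(C(=O)N[C@@H](CC(=O)NCC(C)(C)C)C(=O)N[C@@H](CCc2ccccc2)C(=O)NCc2ccccc2)no1` differs from compound 3 by 5-methyl-1,2-oxazol-3-yl in place of (1H-indol-3-yl)carbonyl on a carbonyl carbon. Going by the values given here, no measured step makes this exact exchange. The steps that vary the same carbonyl carbon are a 2.7-fold higher number from compound 1 to compound 2 (0.43 log units; beyond the scatter), a 2.1-fold higher number from compound 1 to compound 3 (0.32 log units; beyond the scatter) and a 1.3-fold lower number from compound 2 to compound 3 (0.11 log units; within the scatter): three quite different groups at this place gave numbers close together, with only modest movement. Compound 4 is therefore expected to move by about a 1.6-fold higher number from compound 3 to compound 4 (0.20 log units; within the scatter), a small step if any. Compound 4 is estimated at 40 nM, with a range from 15 nM to 110 nM.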

Compound 4, half-maximal inhibitory concentration: 9 nM
Beside the measured number, compound 4's estimate is 4.4-fold (0.65 log units) above it; measured number below the stated range.
By their numbers in this assay, from the lowest: compounds 4 and 1 (each within the scatter of the next); then compounds 3 and 2 (each within the scatter of the next).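

Going by these compounds alone, at this carbonyl carbon in this assay, 5-methyl-1,2-oxazol-3-yl separates from two of the earlier groups, with a 2.8-fold lower number from compound 3 to compound 4 (0.44 log units; beyond the scatter) and a 3.6-fold lower number from compound 2 to compound 4 (0.55 log units; beyond the scatter), so the position responds more than the earlier steps showed. Against phenethyl there is no such separation, with a 1.3-fold lower number from compound 1 to compound 4 (0.12 log units; within the scatter), so two quite different groups here give matching numbers. Nothing measured here accounts for this result. Still open, from the compounds shown here alone, is whether the methyl on the 5-methyl-1,2-oxazol-3-yl matters, and how an ethyl or a carboxylic acid in its place would read.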